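Chloro added to the aryl ring of compound 3

The source may report more compounds than this note shows. Statements on the series, on what has been measured and on what is new or still open speak of the compounds shown alone.

Three compounds have numbers in a functional assay on HOP-62 cells (Homo sapiens) for inhibition, read by sulforhodamine B assay, with a stated time of 48 h; a lower number here means a stronger inhibitor of growth, a higher number a weaker inhibitor of growth. Compound 1 `N#C/C(=C\N1CCN(C(=O)c2ccco2)C1=S)C(=O)Nc1ccc(Cl)cc1` gives 25700 nM, and compound 2 `N#C/C(=C\N1CCN(C(=O)c2ccco2)C1=S)C(N)=O` gives 25600 nM. Among the compounds with values here, the only one-point step among them, a 1.0-fold lower number from compound 1 to compound 2 (0.00 log units; within the scatter), therefore shows no movement. Compound 3 `O=CN1CCN(c2ccc(Cl)cc2)C1=S`, which carries the shared core with a simpler substitution pattern, gives 19100 nM in this assay; this is the lowest of the three numbers shown, but its gap to compound 2 and its gap to compound 1 are both within the scatter, so no order among the three can be claimed.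

Compound 4 `O=CN1CCN(c2ccc(Cl)c(Cl)c2)C1=S` differs from compound 3 by chloro in place of hydrogen on an aromatic carbon. Within the data shown here, no measured step adds a chloro group to an aromatic ring; the single step from compound 1 to compound 2 removes the whole 4-chlorophenyl group and changes nothing, so it bears on the present change only in showing how flat the series has been in this assay so far. A step of about a 1.0-fold lower number from compound 3 to compound 4 (0.00 log units; within the scatter) is expected, that is, none beyond the scatter. Compound 4 is therefore estimated at 19000 nM, with a range from 9000 nM to 40000 nM.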

Compound 4, concentration for 50% growth inhibition: 16100 nM
The estimate for compound 4 lay 1.2-fold (0.07 log units) above the measured number; measured number inside the range.
By their numbers in this assay, from the lowest: compounds 4, 3, 2 and 1 (each within the scatter of the next).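

In this assay, the addition of chloro to the aromatic ring, on the carbon ortho to the chloro group of compound 3 and meta to the group of 8 heavy atoms, gives a 1.2-fold lower number from compound 3 to compound 4 (0.07 log units; within the scatter) and so stays within the scatter. Within the data shown here, this is the first reading on the aryl ring itself: a second chloro is accepted at this carbon with no measurable change in growth inhibition, whereas the earlier step concerned only an amide-type nitrogen in a different part of the series. No data at hand bear on why this change leaves the number where it is.

Among these compounds, still open is whether a different group on this same aromatic carbon, such as a methoxy group, an amine or a carboxylic acid, would move the number in this assay beyond the scatter, since chloro is the only group entering here. Also open, as far as these compounds go, is whether the aryl ring needs any chloro at all, and whether a longer chain in place of the formyl group of compound 4 would separate it from compound 3.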